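The source may report more compounds than this note shows. Statements on the series, on what has been measured and on what is new or still open speak of the compounds shown alone.

Compound 1 `CNC(=O)CCn1nc(-c2ccccc2)ccc1=O`: 3.5%
Compound 2 `N=C(S)CCCCn1nc(-c2ccccc2)ccc1=O`: 33.8%

Compound 2 stands highest of the two numbers in a functional assay on the whole organism (stomach) for inhibition, with Rattus norvegicus as the target, at a dose of 100 mg/kg by the intraduodenal route; a higher number here means more inhibition at the dose given (going by the name of the read-out), a lower number less inhibition; its nearest neighbour is compound 1, which gives 3.5%, and the step of a number 30.3 percentage points higher from compound 1 to compound 2 (beyond the scatter) lies beyond the scatter. Compound 3 `O=c1ccc(-c2ccccc2)nn1CCC(=S)N1CCCC1` has not yet been measured. It differs from compound 2 by a group of 7 heavy atoms (5 carbon, 1 nitrogen, 1 sulfur; one five-membered non-aromatic ring with 1 hetero atom) in place of a group of 5 heavy atoms (3 carbon, 1 nitrogen, 1 sulfur; no ring), on a saturated chain carbon, two bonds along the chain from an aromatic nitrogen. Within the data shown here, the only measured step that bears on this change is the one from compound 1 to compound 2, where a thiocarbonyl-bearing group replaced a carbonyl-bearing group at the same place on the chain and the read-out rose by a number 30.3 percentage points higher from compound 1 to compound 2 (beyond the scatter). Compound 3 keeps a thiocarbonyl but loses both hydrogen-bond donors and gains a five-membered non-aromatic ring, so the measured step gives no firm pointer in either direction. The expected step of a number 8.8 percentage points lower from compound 2 to compound 3 (within the scatter) is therefore small, a modest fall that may stay within the scatter. Compound 3 is estimated to give 25% in this assay, with a range from 5% to 50%.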

Compound 3, a percentage reported as inhibition, in the whole organism at one dose (the size of the read-out at that dose, not a potency): 38.2%
The estimate for compound 3 lay 13.2 percentage points below the measured number, within the range that was stated.
By their numbers in this assay, from the lowest: compound 1; then compounds 2 and 3 (each within the scatter of the next).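

In this assay, the step of a number 4.4 percentage points higher from compound 2 to compound 3 (within the scatter) shows that, at this saturated chain carbon, the group with the five-membered non-aromatic ring can take the place of the open-chain group of compound 2, with its hydrogen-bond donors, without a difference beyond the scatter. Measured against the carbonyl-bearing group of compound 1, the same ring-bearing group gives a number 34.7 percentage points higher from compound 1 to compound 3 (beyond the scatter), so both thiocarbonyl-bearing groups now stand clear of compound 1, and neither of the two compounds goes against this. Nothing measured here accounts for these numbers or links them to any property of the groups.

The compounds shown leave open whether the five-membered ring would give a similar number with a carbonyl in place of the thiocarbonyl, which would separate the two parts of the change from compound 1 to compound 3. They also leave open how a piperidine ring, a morpholine ring or a longer chain would read at this place.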